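The source may report more compounds than this note shows. Statements on the series, on what has been measured and on what is new or still open speak of the compounds shown alone.

Of the compounds shown here, two of the same core have been measured so far. Compound 1, `CN1CC(c2ccc(Cl)cc2)[C@@]2(NC(=S)N(c3ccc(F)c(Cl)c3)C2=O)[C@@]12C(=O)Nc1ccc(Br)cc12`, gives 6840 nM in a functional assay on MCF7 cells (Homo sapiens) for cytotoxicity, read by MTT assay, with a stated time of 48 h; a higher number here means a weaker inhibitor, a lower number a stronger inhibitor. Compound 2, `CC(C)Oc1ccc(C2CN(C)[C@]3(C(=O)Nc4ccc(Br)cc43)[C@]23NC(=S)N(c2ccc(F)c(Cl)c2)C3=O)cc1`, carries an isopropoxy group where compound 1 carries a chloro group, and in this assay compound 2 gives 34900 nM; that single exchange produced a 5.1-fold higher number from compound 1 to compound 2 (0.71 log units; beyond the scatter), so compound 2 stands as the higher of the two numbers shown, meaning the weaker inhibitor of the pair.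

Compound 3, `CC(C)Oc1ccc(C2CN(C)[C@]3(C(=O)Nc4ccccc43)[C@]23NC(=S)N(c2ccc(F)c(Cl)c2)C3=O)cc1`, keeps everything of compound 2 except one substituent: hydrogen in place of bromo on an aromatic carbon. Among the measured compounds shown here, no measured pair shows this particular change, so the only guide is the overall level set by compound 2 and the one step already seen, which involved a different position and different groups. With nothing to point in either direction, the expectation is that compound 3 stays close to compound 2, with the step of a 1.4-fold higher number from compound 2 to compound 3 (0.16 log units; within the scatter) estimated as small and the uncertainty wide. Compound 3 is therefore expected to give about 50000 nM in this assay, within a range of 15000 nM to 150000 nM.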

Compound 3, half-maximal inhibitory concentration: 20200 nM
Estimate against measurement, compound 3: 2.5-fold (0.39 log units) above, within the range that was stated.
By their numbers in this assay, from the lowest: compound 1; then compounds 3 and 2 (each within the scatter of the next).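

Hydrogen in place of bromo, on an aromatic carbon that is meta to a fused ring and para to a fused ring, gives a 1.7-fold lower number from compound 2 to compound 3 (0.24 log units; within the scatter) in this assay. Among the compounds shown here, this is the first look at this position, and it shows that, with the isopropoxy group in place, the bromo can be exchanged for hydrogen without a step that stands out from the ordinary spread of repeated measurements, so compound 2 and compound 3 cannot be told apart in this assay. Nothing shown here explains why the number responds so little to this exchange.

Still open, as far as these compounds go, is whether the same exchange would also be this small with the chloro group of compound 1 in place of the isopropoxy group, since a step at one position can depend on what the rest of the molecule carries. Also open, from the compounds shown here alone, is what other groups on this aromatic carbon would do, for example an amine, a carboxylic acid or a longer chain such as an ethoxy group, and whether any of them would move the number beyond the scatter in either direction.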